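From methyl to methoxy: compound 2 to compound 3

This account rests on a few compounds, and the source may have more. Where it says the series, first, only, none or still open, it means among the compounds named here.

In a functional assay on HL-60 cells (Homo sapiens) for cytotoxicity, read by MTT assay, with a stated time of 72 h (a higher number here means a weaker inhibitor, a lower number a stronger inhibitor), compound 1 (`COc1ccc(Nc2nc3ccccc3nc2S(=O)(=O)c2ccc(C)cc2)cc1`) gives 2790 nM and compound 2 (`Cc1ccc(S(=O)(=O)c2nc3ccccc3nc2Nc2cccc(N)c2)cc1`) gives 1080 nM as the lower of the two numbers. Among the compounds with values here, the only measured step is a 2.6-fold lower number from compound 1 to compound 2 (0.41 log units; beyond the scatter) and it comes with 3-aminophenyl in place of 4-methoxyphenyl on a nitrogen on an aromatic ring. That step is modest but beyond the scatter. Compound 3 (`COc1ccc(S(=O)(=O)c2nc3ccccc3nc2Nc2cccc(N)c2)cc1`) keeps the 3-aminophenyl of compound 2 and differs elsewhere (methoxy in place of methyl on an aromatic carbon) with methoxy in place of methyl on an aromatic carbon, para to a large group. Within the data shown here, no measured step covers this place, and the data give no direction for it. With only a 2.6-fold lower number from compound 1 to compound 2 (0.41 log units; beyond the scatter) as a guide, nothing larger than a modest step is expected in this assay here. The expected change is a 1.1-fold higher number from compound 2 to compound 3 (0.05 log units; within the scatter) and would stay within the scatter. For compound 3 the estimated value is 1200 nM (expected range 500 nM to 2800 nM).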

Compound 3, half-maximal inhibitory concentration: 1490 nM
Compound 3: middle estimate off by 1.2-fold (0.09 log units), on the low side; the measured number falls inside the stated range.
By their numbers in this assay, from the lowest: compounds 2, 3 and 1 (each within the scatter of the next, the first and the last beyond it).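

Working notes on the second place varied in the series, the aromatic carbon para to a large group. With the 3-aminophenyl held constant, methoxy in place of methyl gives a 1.4-fold higher number from compound 2 to compound 3 (0.14 log units; within the scatter) in this assay and so does not separate the two groups at this place. Within the data shown here, the swap from 4-methylphenyl to 4-methoxyphenyl adds one heavy atom and one hydrogen-bond acceptor, yet the number stays within the scatter, whereas the change on the nitrogen remains the only step beyond it. No supporting measurement bears on this result.

Only methyl and methoxy are shown at this place, so a single pair cannot tell how a group of another kind, such as chlorine, an amine or a carboxylic acid, would read there. Going by these compounds, it also remains open whether methoxy in place of methyl would read the same with the 4-methoxyphenyl of compound 1 on the nitrogen rather than the 3-aminophenyl shared by compound 2 and compound 3.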